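The source may report more compounds than this note shows. Statements on the series, on what has been measured and on what is new or still open speak of the compounds shown alone.

Measured so far in a functional assay on SH-SY5Y cells (Homo sapiens) for inhibition, read by sulforhodamine B assay; a lower number here means a stronger inhibitor, a higher number a weaker inhibitor: compound 1 `COC(=O)CC/C(C)=C/Cc1c(OC)c(C)c2c(c1OCC#CCN1CCN(c3ccc(C)cc3)CC1)C(=O)OC2` gives 37700 nM. Compound 3 `COC(=O)CC/C(C)=C/Cc1c(OC)c(C)c2c(c1OCC#CCN1CCN(C(c3ccc(F)cc3)c3ccc(F)cc3)CC1)C(=O)OC2` gives 25800 nM. Compound 2 `COC(=O)CC/C(C)=C/Cc1c(OC)c(C)c2c(c1OCC#CCN1CCN(C(=O)C3COc4ccccc4O3)CC1)C(=O)OC2` gives > 50000 nM, which is a limit of the assay and not a number.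

Going by the values given here, compound 2 therefore stands apart from the other two: it is the one compound of the three that reached the limit of > 50000 nM in this assay, at which 1 of the 3 values shown sits, and returned no number in this assay. Among the compounds with values here, the one measured step that involves it is an at least 1.3-fold higher number from compound 1 to compound 2 (0.12 log units; that floor lies within the scatter), a change whose floor lies within the usual scatter, so it says only that compound 2 is not stronger than compound 1.

Compound 4 `COC(=O)CC/C(C)=C/Cc1c(OC)c(C)c2c(c1OCC#CCN1CCN(c3ccccc3OC)CC1)C(=O)OC2` is the next compound. Relative to compound 2 it carries 2-methoxyphenyl in place of (2,3-dihydro-1,4-benzodioxin-2-yl)carbonyl on an amine nitrogen in a ring. This change returns to an aromatic ring sitting directly on the ring nitrogen, as in compound 1, and removes the carbonyl. The step that bears on it is an at least 1.3-fold higher number from compound 1 to compound 2 (0.12 log units; that floor lies within the scatter) read backwards, pointing to a number at or below the limit, in the region of compound 1 and compound 3.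

Compound 4 is therefore expected to give about 35000 nM in this assay, with a range from 15000 nM to 80000 nM. That estimate means an at least 1.4-fold lower number from compound 2 to compound 4 (0.15 log units; that floor lies within the scatter), a move back into the measurable region.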

Compound 4, half-maximal inhibitory concentration: 43600 nM
Compound 4: middle estimate off by 1.2-fold (0.10 log units), on the low side; measured number inside the range.
By their numbers in this assay, from the lowest: compounds 3, 1 and 4 (each within the scatter of the next). At a limit, above all of these: compound 2.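

In this assay, placing 2-methoxyphenyl instead of 4-methylphenyl on the ring nitrogen gives a 1.2-fold higher number from compound 1 to compound 4 (0.06 log units; within the scatter), so these two aromatic groups cannot be told apart in this assay, even though they differ in what they carry on the ring. Replacing the (2,3-dihydro-1,4-benzodioxin-2-yl)carbonyl group with 2-methoxyphenyl gives an at least 1.1-fold lower number from compound 2 to compound 4 (0.05 log units; that floor lies within the scatter), and since this is only a floor within the scatter, it does not establish that the swap improves inhibition. Compound 2 therefore remains defined by a limit of the assay rather than by a number: the limit of > 50000 nM in this assay, at which 1 of the 4 values shown sits.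

The compounds shown leave open whether the carbonyl or the 2,3-dihydro-1,4-benzodioxin-2-yl part matters more for the result of compound 2, a question that a benzoyl group on the same nitrogen could help to separate. They also leave open whether any group on this nitrogen can bring a clear gain, or whether a different part of the molecule, such as a carboxylic acid in place of the methyl ester, would have a larger effect on the number.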